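Removing the Carboxy Group from Compound 2

The compounds below may be only part of what the source reports. "The series", "measured", "known", "first", "only" and "open" are said of these compounds alone.

Going by the values given here, compound 2 `CC(=N)N1CCC(Oc2ccc3nc(CCC(=O)O)n(Cc4ccc5ccc(C(=N)N)cc5c4)c3c2)CC1` gives the highest of the two numbers so far in an assay on isolated protein for inhibition of serine protease 1 (Bos taurus); on this read-out lower numbers stand for stronger inhibition and higher numbers for weaker inhibition: compound 2 gives 18 nM, whereas compound 1 `CCCc1nc2ccc(OC3CCN(C(C)=N)CC3)cc2n1Cc1ccc2ccc(C(=N)N)cc2c1` gives 6.8 nM. The step of a 2.6-fold higher number from compound 1 to compound 2 (0.42 log units; beyond the scatter) lies beyond the scatter, so compound 2 is the weaker inhibitor of the pair. Compound 3 `CCc1nc2ccc(OC3CCN(C(C)=N)CC3)cc2n1Cc1ccc2ccc(C(=N)N)cc2c1` has not yet been measured. Compound 3 differs from compound 2 by hydrogen in place of carboxy on a saturated chain carbon, two bonds along the chain from an aromatic carbon. Among the compounds with values here, the only measured step that bears on this change is the one in which carboxy entered in place of methyl on the same saturated chain carbon, a 2.6-fold higher number from compound 1 to compound 2 (0.42 log units; beyond the scatter), a modest rise. The change to compound 3 takes the carboxy away again, and compound 3 then carries an ethyl chain where compound 1 carries a propyl chain. Because a 2.6-fold higher number from compound 1 to compound 2 (0.42 log units; beyond the scatter) was modest, compound 3 is expected to show a step of about a 2.3-fold lower number from compound 2 to compound 3 (0.35 log units; beyond the scatter) back toward the number of compound 1. Compound 3 is therefore estimated to give 8 nM in this assay, within a range from 3 nM to 20 nM.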

Compound 3, inhibition constant: 7.7 nM
For compound 3 the middle estimate is 1.0-fold (0.02 log units) above the measured one, and the stated range covers the measured number.
By their numbers in this assay, from the lowest: compounds 1 and 3 (each within the scatter of the next); then compound 2.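

Read from the ethyl chain, the carboxy group now has a clean comparison of its own in this assay: removing it gives a modest step beyond the scatter (a 2.3-fold lower number from compound 2 to compound 3 (0.37 log units; beyond the scatter)), so the 2-carboxyethyl chain and the ethyl chain can be told apart on this read-out. Hydrogen in place of methyl on the same saturated chain carbon gives a step within the scatter (a 1.1-fold higher number from compound 1 to compound 3 (0.05 log units; within the scatter)), so the propyl and ethyl chains cannot be told apart, and the earlier rise with carboxy is not matched by any readable change between these two plain chains. Nothing measured here gives a reason for either step.

The compounds shown leave open whether carboxy on a shorter chain, as a carboxymethyl group, would give a step of the same size, and whether an ester or an amide made from the carboxylic acid would read like compound 2 or like compound 3. They also leave open whether a longer chain such as butyl, or an amine at the end of the ethyl chain, would stay within the scatter of compound 3.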